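A Second Fluorine on the Urea Phenyl Ring

A few compounds are considered here, and "the series" means these few. Any claim that something is new, unique, unknown or untested is made for them only; others in the source may bear on it.

Compound 1 `Cc1ccccc1NC(=O)N[C@H](C)c1ccccc1` gives 99% in an ADME assay on the whole organism with Oryza sativa as the target, tested at 10 uM; a lower number here means a stronger effect, a higher number a weaker effect of the compound at the concentration tested.
Compound 2 `C[C@@H](NC(=O)Nc1ccccc1F)c1ccccc1` gives 77% in this assay.
Compound 3 `C[C@@H](NC(=O)Nc1ccccc1I)c1ccccc1` gives 96% in this assay.

Compound 2 holds the lowest of the three numbers; the step of a number 22 percentage points lower from compound 1 to compound 2 (beyond the scatter) and the step of a number 19 percentage points higher from compound 2 to compound 3 (beyond the scatter) set it apart from both neighbours. The unmeasured compound 4 `C[C@@H](NC(=O)Nc1ccc(F)cc1F)c1ccccc1` differs from compound 2 by fluoro in place of hydrogen on an aromatic carbon. For the measured compounds named here, no measured step adds a fluoro group to a ring already carrying one; the two steps that involve compound 2 each exchange the single substituent and move the number only modestly. Without a direct guide, the added fluoro is expected to change the number little, probably not beyond the scatter. For compound 4 the estimate is 80%, between 65% and 95%. This is expected to amount to a step of a number 3 percentage points higher from compound 2 to compound 4 (within the scatter).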

Compound 4, a percentage reported as activity, at one concentration (the size of the read-out at that concentration, not a potency): 93%
For compound 4 the middle estimate is 13 percentage points below the measured one, and the stated range covers the measured number.
By their numbers in this assay, from the lowest: compound 2; then compounds 4, 3 and 1 (each within the scatter of the next).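

The earlier steps shown here only exchanged the single ring substituent, whereas here a hydrogen para to a large group gives way to fluoro, and this assay records a number 16 percentage points higher from compound 2 to compound 4 (beyond the scatter). This position therefore matters: the low number of compound 2 depends on it carrying hydrogen as well as on the existing fluoro group. No available measurement gives a reason for this step. Still open, going by these compounds, is whether a methoxy group or an amine at this position would move the number in the same way. Also open, on these data alone, is what fluoro here would do on a ring without the first fluoro group.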